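Metabolic stability notes: acetyl in place of the amide chain

The source may report more compounds than this note shows. Statements on the series, on what has been measured and on what is new or still open speak of the compounds shown alone.

Measured so far:
compound 1 `CC(C)CCn1nc(-c2cccs2)c(O)c(C2=NS(=O)(=O)c3cc(OCC(=O)NO)ccc3N2)c1=O` – > 1 h
compound 2 `CC(C)CCn1nc(-c2cccs2)c(O)c(C2=NS(=O)(=O)c3cc(CCC(N)=O)ccc3N2)c1=O` – > 1 h

Compound 1 `CC(C)CCn1nc(-c2cccs2)c(O)c(C2=NS(=O)(=O)c3cc(OCC(=O)NO)ccc3N2)c1=O` carries (hydroxycarbamoyl)methoxy on its core. In an in vitro ADME assay on microsomes from liver (Homo sapiens) for metabolic stability, tested at 5 uM (a higher number here means that the compound lasts longer, a lower number that the compound disappears faster), compound 1 reaches the assay limit, > 1 h. Compound 2 `CC(C)CCn1nc(-c2cccs2)c(O)c(C2=NS(=O)(=O)c3cc(CCC(N)=O)ccc3N2)c1=O` carries 2-carbamoylethyl in that place. In this assay compound 2 likewise reaches the limit, > 1 h. The comparison gives a step that the two limits leave unreadable from compound 1 to compound 2; both values sit at the limit of > 1 h in this assay, at which 2 of the 2 values shown sit. Compound 2 therefore stands at the ceiling of what has been read, with no numerical half-life resolved.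

Compound 3 `CC(=O)c1ccc2c(c1)S(=O)(=O)N=C(c1c(O)c(-c3cccs3)nn(CCC(C)C)c1=O)N2` differs from compound 2 as follows: acetyl in place of 2-carbamoylethyl on an aromatic carbon. Among the measured compounds shown here, no measured step bears on this change, and the single measured step is unreadable, so the expected size of the step in this assay cannot be anchored in a measured comparison. For compound 3 the step expected is a step that the limit leaves unreadable from compound 2 to compound 3. For compound 3 the estimated half-life in this assay is 1.3 h, with a range from 0.5 h to 3 h, and a fair chance that the assay again reports only a limit.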

Compound 3, half-life: 0.0717 h
Compound 3: middle estimate off by 18-fold (1.26 log units), on the high side; the whole stated range lies above it.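

In this assay, the position on the aromatic carbon now shows that the group placed there matters for half-life. Acetyl in place of 2-carbamoylethyl gives an at least 13-fold lower number from compound 2 to compound 3 (1.14 log units; beyond the scatter), and acetyl in place of (hydroxycarbamoyl)methoxy gives an at least 13-fold lower number from compound 1 to compound 3 (1.14 log units; beyond the scatter). Both sizes are bounds rather than exact differences, and the step between compound 1 and compound 2 cannot be read, so the two longer groups cannot be ranked against each other: the limit of > 1 h in this assay, at which 2 of the 3 values shown sit.

As far as these compounds go, it remains open whether the drop follows from the ketone carbonyl of acetyl or from the shorter group, with 3 heavy atoms in place of 5. A ketone carried on a longer chain, or a short group such as an amine or a carboxylic acid at this position, would bear on that question.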